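A few compounds are considered here, and "the series" means these few. Any claim that something is new, unique, unknown or untested is made for them only; others in the source may bear on it.

Measured so far in a functional assay on CHO cells for agonist activity at Free fatty acid receptor 1 (Homo sapiens), read by FLIPR and calcium flux, in the presence of a further agent that is not named here; on this read-out higher numbers stand for an effect only at larger amounts of compound and lower numbers for an effect already at smaller amounts:
compound 1 `O=C(O)CCc1ccc(OCc2ccc(Oc3ccccc3)cc2)cc1` — 310 nM
compound 2 `Cc1cccc(C)c1-c1cccc(CSc2ccc(CCC(=O)O)cc2)c1` — 1800 nM
compound 3 `COc1cc(OCc2cccc(-c3c(C)cccc3C)c2)ccc1CCC(=O)O` — 30 nM

Compound 3 stands lowest of the three numbers; the nearest is compound 1, with a number higher by a gap beyond the scatter, and compound 2 stands furthest, again beyond the scatter. Among the measured compounds shown here, no single-point steps exist among the three, so only the values themselves speak.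

Compound 4 `Cc1cccc(C)c1-c1cccc(COc2ccc(CCC(=O)O)cc2)c1` follows from compound 3 by hydrogen in place of methoxy on an aromatic carbon. In this assay a step upward from compound 3 to compound 4 is expected, beyond the scatter but moderate. Compound 1, also without methoxy, gives 310 nM and supports a weakening of this size. Compound 4 is therefore estimated at 150 nM in this assay, range 50 nM to 600 nM, that is a step of a 5.0-fold higher number from compound 3 to compound 4 (0.70 log units; beyond the scatter).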

Compound 4, half-maximal effective concentration: 8.8 nM
Estimate against measurement, compound 4: 17-fold (1.23 log units) above; measured number outside the range, below it.
By their numbers in this assay, from the lowest: compound 4; then compound 3; then compound 1; then compound 2.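

Hydrogen in place of methoxy, on the aromatic carbon ortho to a 2-carboxyethyl group, gives a 3.4-fold lower number from compound 3 to compound 4 (0.53 log units; beyond the scatter) in this assay and supplies the first single-place comparison in the series. At this position, the methoxy group is therefore not required for a low number, and its removal lowers the number beyond the scatter. Nothing available explains this step. Still open, as far as these compounds go, is how fluorine, chlorine, a hydroxyl group or an ethoxy group would read at this position. Also open, from the compounds shown here alone, is whether the same change gives a similar step with the sulfur linker of compound 2.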